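Swapping a Bromophenyl for a Pyridinyl in a Dienone Series

The compounds below may be only part of what the source reports. "The series", "measured", "known", "first", "only" and "open" are said of these compounds alone.

Compound 1 `CC1=C(/C=C/C(=O)/C=C/c2ccc(Cl)cc2)C(C)(C)CCC1` gives 33200 nM in a functional assay on HeLa cells (Homo sapiens) for cytotoxicity, read by sulforhodamine B assay, with a stated time of 48 h; on this read-out lower numbers stand for stronger inhibition and higher numbers for weaker inhibition.
Compound 2 `CC1=C(/C=C/C(=O)/C=C/c2ccc(Br)cc2)C(C)(C)CCC1` gives 88800 nM in this assay.
Compound 3 `CC1=C(/C=C/C(=O)/C=C/c2ccccc2Br)C(C)(C)CCC1` gives 57900 nM in this assay.

Of the compounds shown here, three sharing one core have been measured. Compound 3 sits close to both neighbours: the gap a 1.5-fold lower number from compound 2 to compound 3 (0.19 log units; within the scatter) and the gap a 1.7-fold higher number from compound 1 to compound 3 (0.24 log units; within the scatter) are each within the scatter, so none of these three can be separated from compound 3. Among the measured compounds shown here, the only step beyond the scatter is a 2.7-fold higher number from compound 1 to compound 2 (0.43 log units; beyond the scatter), a modest move between two halogens.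

Compound 4 `CC1=C(/C=C/C(=O)/C=C/c2cccnc2)C(C)(C)CCC1` carries the change (pyridin-3-yl in place of 2-bromophenyl on a double-bonded chain carbon bound to a double-bonded chain carbon). For the measured compounds named here, no measured step exchanges a halogen-bearing ring for a nitrogen-containing ring, so the direction rests on weak ground. The measured steps show that changes on this ring shifted the number only modestly, so a similarly small shift, probably a slight weakening, is expected for compound 4, expressed as a 1.2-fold higher number from compound 3 to compound 4 (0.08 log units; within the scatter). Compound 4 is estimated at 70000 nM, with a range from 25000 nM to 200000 nM, in this assay.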

Compound 4, half-maximal inhibitory concentration: 17400 nM
Beside the measured number, compound 4's estimate is 4.0-fold (0.60 log units) above it, outside the stated range (below it).
By their numbers in this assay, from the lowest: compounds 4, 1, 3 and 2 (each within the scatter of the next, the first and the last beyond it).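

Among the compounds shown here, this is the first exchange at this place of a halogen-bearing phenyl ring for a ring holding a nitrogen, and in this assay it gives steps beyond the scatter against both bromine compounds, with a 3.3-fold lower number from compound 3 to compound 4 (0.52 log units; beyond the scatter) and with a 5.1-fold lower number from compound 2 to compound 4 (0.71 log units; beyond the scatter) as well. Against the chlorine compound the same exchange separates nothing, with a 1.9-fold lower number from compound 1 to compound 4 (0.28 log units; within the scatter) staying within the scatter, so a halogen on this ring is not needed to reach the level of compound 1. Nothing shown here explains why the pyridin-3-yl ring parts from the bromophenyl rings but not from the chlorophenyl ring.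

Pyridin-2-yl and pyridin-4-yl rings would test whether the place of the ring nitrogen matters. A plain phenyl ring would show what the halogen itself contributes when compared with these compounds.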